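Removing one methoxy from the trimethoxyphenyl end

A few compounds are considered here, and "the series" means these few. Any claim that something is new, unique, unknown or untested is made for them only; others in the source may bear on it.

For the measured compounds named here, compound 1 `COc1cc(/C=C/C(=O)/C=C/c2cc(OC)c(OC)c(OC)c2)ccc1OCc1cn(CCCCCOc2cc(=O)oc3ccccc23)nn1` gives 51% in a functional assay on COLO 205 cells (Homo sapiens) for inhibition, read by sulforhodamine B assay, with a stated time of 48 h, tested at 50 uM (a higher number here means more inhibition of growth at the concentration tested, a lower number less inhibition of growth), and stands highest of the two numbers measured so far. Going by the values given here, compound 2 `COc1cc(/C=C/C(=O)/C=C/c2ccccc2)ccc1OCc1cn(CCCCOc2cc(=O)oc3ccccc23)nn1` gives 31% in this assay, a lower reading that lies beyond the usual scatter; compound 2 differs from compound 1 in more than one place, so the pair yields no single step.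

Compound 3 `COc1ccc(/C=C/C(=O)/C=C/c2ccc(OCc3cn(CCCCCOc4cc(=O)oc5ccccc45)nn3)c(OC)c2)cc1OC` is the next to be measured. Its change from compound 1 is hydrogen in place of methoxy on an aromatic carbon; read one bond further out, the 3,4,5-trimethoxyphenyl becomes a 3,4-dimethoxyphenyl. Among the compounds with values here, no measured pair isolates this change. Given that compound 2, bare of methoxy groups on that ring, gives 31%, a modest step downward is expected from compound 1 to compound 3, a number 8 percentage points lower from compound 1 to compound 3 (within the scatter), quite possibly within the scatter. Compound 3 is estimated at 43%, expected between 28% and 58%.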

Compound 3, percent growth inhibition at one concentration: 43%
Beside the measured number, compound 3's estimate shows no gap at the digits printed, and the stated range covers the measured number.
By their numbers in this assay, from the lowest: compound 2; then compounds 3 and 1 (each within the scatter of the next).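

In this assay, for the compounds shown here, hydrogen in place of methoxy on this aromatic carbon gives a number 8 percentage points lower from compound 1 to compound 3 (within the scatter) as the first step that can be read at a single place. The 3,4,5-trimethoxyphenyl and 3,4-dimethoxyphenyl ends are therefore not separated at the one concentration tested, so this methoxy, ortho to a methoxy group and meta to a large group, is not shown to matter to the reading. No measurement at hand bears on the reason for this result.

Compound 2 differs from compound 3 in more than one place, so the contribution of the two remaining methoxy groups stays unresolved. Also open, going by these compounds, is how a hydroxy group, a fluorine atom or an amine would read at this position.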